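Chloro in place of nitro: working notes on compound 1

The source may report more compounds than this note shows. Statements on the series, on what has been measured and on what is new or still open speak of the compounds shown alone.

Within the data shown here, compound 1 `O=[N+]([O-])c1ccc(/C=N/Cc2cccnc2)cc1` is one of two compounds measured in a functional assay on the whole organism (strain Swiss albino) with Mus musculus as the target, in the maximal electroshock model; a higher number here means that more compound is needed for the effect, a lower number that less compound is needed. In this assay compound 1 gives 61.4 mg/kg, the highest of the two numbers. The nearest is compound 2 `C(=C/c1ccccc1)\C=N\Cc1cccnc1`, which in this assay gives 36.3 mg/kg; the gap between the two lies within the scatter, so nothing separates them. Among the measured compounds shown here, no step between measured compounds that differ in one place is available. Compound 3 `Clc1ccc(/C=N/Cc2cccnc2)cc1` has not been measured. It differs from compound 1 by chloro in place of nitro on an aromatic carbon. For the measured compounds named here, with no comparable step in hand, the step is expected to be small, not beyond the scatter, with a slight lean toward a lower number. The expected step is a 1.4-fold lower number from compound 1 to compound 3 (0.13 log units; within the scatter). For compound 3 the estimate in this assay is 45 mg/kg, with a range from 20 mg/kg to 110 mg/kg.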

Compound 3, dose for half-maximal effect: 53 mg/kg
Compound 3: middle estimate off by 1.2-fold (0.07 log units), on the low side; the measured number falls inside the stated range.
By their numbers in this assay, from the lowest: compounds 2, 3 and 1 (each within the scatter of the next).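

Among these compounds, this is the first one-place step: in this assay, chloro in place of nitro on an aromatic carbon gives a 1.2-fold lower number from compound 1 to compound 3 (0.06 log units; within the scatter), so the step stays within the scatter. At this position, para to a group of 9 heavy atoms, nitro with 3 heavy atoms and 2 hydrogen-bond acceptors and chloro with 1 heavy atom and 0 hydrogen-bond acceptors are therefore not separated by this read-out. No measured property bears on this result.

Still open, as far as these compounds go, is whether any group at this position moves the number beyond the scatter, for instance an amine, a methoxy or a carboxylic acid. The compounds shown also leave open whether chloro would give the same result elsewhere on the ring.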